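A few compounds are considered here, and "the series" means these few. Any claim that something is new, unique, unknown or untested is made for them only; others in the source may bear on it.

Working notes on the series, measured in an in vitro ADME assay on microsomes from liver (Homo sapiens) for metabolic stability, tested at 5 uM; a lower number here means that the compound disappears faster, a higher number that the compound lasts longer:

- Compound 1 `COCN(c1ccc2c(c1)S(=O)(=O)N=C(c1c(O)c(-c3cccs3)nn(CCC(C)C)c1=O)N2)S(C)(=O)=O`: 0.183 h
- Compound 2 `CC(C)CCn1nc(-c2cccs2)c(O)c(C2=NS(=O)(=O)c3cc(S(=O)(=O)N(C)C)ccc3N2)c1=O`: 0.183 h
- Compound 3 `CC(C)CCn1nc(C2CCCC2)c(O)c(C2=NS(=O)(=O)c3cc(NS(C)(=O)=O)ccc3N2)c1=O`: 0.283 h

Compound 3, at 0.283 h, lies within the usual scatter of both compound 1 and compound 2, so the three measured compounds form a single level in this assay.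

The next compound to be measured is compound 4 `CC(C)=Cc1nn(CCC(C)C)c(=O)c(C2=NS(=O)(=O)c3cc(NS(C)(=O)=O)ccc3N2)c1O`. Its structural change from compound 3 is 2-methylprop-1-en-1-yl in place of cyclopentyl on an aromatic carbon. The group sits on an aromatic carbon ortho to a hydroxy group.

Among the measured compounds shown here, only one measured step is available, no change at the digits printed from compound 1 to compound 2 (within the scatter). That step concerns a different group, and it stays within the scatter. For the measured compounds named here, no measured step changes only the group on this aromatic carbon, so the data give no direct size for this replacement. The expectation therefore rests on the flat level of the three values and on compound 3 at 0.283 h as the starting point. No shift beyond the scatter is expected in this assay, and no direction is favoured with any confidence.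

The expected change is a 1.3-fold lower number from compound 3 to compound 4 (0.13 log units; within the scatter), an estimate that stays within the scatter.

For compound 4 the estimated half-life is 0.21 h, with an expected range of 0.11 h to 0.4 h.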

Compound 4, half-life: 0.55 h
Compound 4: middle estimate off by 2.6-fold (0.42 log units), on the low side, outside the stated range (above it).
By their numbers in this assay, from the lowest: compounds 1, 2, 3 and 4 (each within the scatter of the next, the first and the last beyond it).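

In this assay, among the compounds shown here, the exchange of cyclopentyl for 2-methylprop-1-en-1-yl on the aromatic carbon ortho to a hydroxy group gives a 1.9-fold higher number from compound 3 to compound 4 (0.29 log units; within the scatter), which is the first measured step at this position. Replacing the five-membered carbon ring with an open group carrying a double bond outside aromatic rings therefore leaves the half-life within the scatter, and between these two groups the ring is not needed to hold that level. Nothing measured here accounts for this step.

Going by these compounds, whether an isobutyl chain, a longer chain, an amine or a carboxylic acid on this aromatic carbon would shift the half-life beyond the scatter remains open, since the two groups compared here span only a narrow range of structures. On these data alone, compound 1 and compound 2 differ from compound 3 and compound 4 in more than one place, so it also remains open how the group on this carbon behaves when the other substituent on the core is dimethylsulfamoyl or (methoxymethyl)(methylsulfonyl)amino.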